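Methyl to Ethyl: A Small Step on the Shared Core

This account rests on a few compounds, and the source may have more. Where it says the series, first, only, none or still open, it means among the compounds named here.

Of the compounds shown here, two have been tested in a functional assay on SK-BR-3 cells (Homo sapiens) for antiproliferative activity; a lower number here means that less compound is needed, a higher number that more compound is needed for the effect. Compound 1 `CCOC(=O)C(=O)Nc1nc2ccc(NC(=O)c3cc(Br)c[nH]3)cc2s1` gives 27900 nM in this assay, while compound 2 `CCOC(=O)C(=O)Nc1ccc2nc(NC(=O)c3cc4cc(C)ccc4[nH]3)sc2c1` gives 2810 nM. Compound 2 thus stands at the lower of the two numbers, and its gap to compound 1 lies beyond the usual scatter. Compound 3 `CCOC(=O)C(=O)Nc1ccc2nc(NC(=O)c3cc4cc(CC)ccc4[nH]3)sc2c1` differs from compound 2 only by methyl in place of hydrogen on a saturated chain carbon bound to an aromatic carbon. Going by the values given here, no measured pair shows this change, so the step is expected to be small, with no direction beyond the scatter: a 1.1-fold lower number from compound 2 to compound 3 (0.05 log units; within the scatter). Compound 3 is therefore estimated at 2500 nM, within a range from 900 nM to 7000 nM.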

Compound 3, half-maximal effective concentration: 20600 nM
Estimate against measurement, compound 3: 8.2-fold (0.92 log units) below; the whole stated range lies below it.
By their numbers in this assay, from the lowest: compound 2; then compounds 3 and 1 (each within the scatter of the next).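

In this assay, the change from methyl to ethyl on the shared core proves to be a real step: a 7.3-fold higher number from compound 2 to compound 3 (0.87 log units; beyond the scatter). Going by these compounds alone, this position therefore responds to a single added carbon, something the earlier compounds could not show, as they differ in more than one place. No measurement here explains the step.

From the compounds shown here alone, whether a longer chain such as propyl would raise the number further remains open. So does whether a different group at this place, such as an amine or a carboxylic acid, would bring it back down.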